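A few compounds are considered here, and "the series" means these few. Any claim that something is new, unique, unknown or untested is made for them only; others in the source may bear on it.

Measured compounds:
compound 1 `COC(=O)CC(=O)N1N=C(c2ccc(N3CCN(C)CC3)cc2)CC1c1ccc(N(C)C)cc1` — -8.3%
compound 2 `Cc1ccc(C(=O)N2N=C(c3ccc(N4CCN(C)CC4)cc3)CC2c2ccc(N(C)C)cc2)cc1` — -2.5%

Both numbers come from a functional assay on HCC1806 cells (Homo sapiens) for inhibition, read by sulforhodamine B assay, tested at 10 uM; a lower number here means less inhibition, a higher number more inhibition at the concentration tested (going by the name of the read-out). Within the data shown here, compound 1 and compound 2 lie within the scatter of each other, and neither shows inhibition beyond the scatter; the only measured step, a number 5.8 percentage points higher from compound 1 to compound 2 (within the scatter), is the exchange of the whole group on the carbonyl carbon and stays within the scatter.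

Compound 3 `CN1CCN(c2ccc(C3=NN(C(=O)c4ccc(F)cc4)C(c4ccc(N(C)C)cc4)C3)cc2)CC1` has not been measured. It differs from compound 2 by fluoro in place of methyl on an aromatic carbon. Among the measured compounds shown here, no measured step touches this position, so the nearest guide is that compound 1 and compound 2 sit at the same flat level despite a larger change at the carbonyl. A step beyond the scatter is therefore not expected in this assay for compound 3, and the estimated change a number 2.5 percentage points higher from compound 2 to compound 3 (within the scatter) is small. Compound 3 is expected to give 0%, with a range from -15% to 15%.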

Compound 3, a percentage reported as inhibition, at one concentration (the size of the read-out at that concentration, not a potency): 31.8%
For compound 3 the middle estimate is 31.8 percentage points below the measured one; the measured number lies above the stated range.
By their numbers in this assay, from the lowest: compounds 1 and 2 (each within the scatter of the next); then compound 3.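

Fluoro in place of methyl on an aromatic carbon, para to a large group, gives a number 34.3 percentage points higher from compound 2 to compound 3 (beyond the scatter) in this assay, so this position is not silent even though only one heavy atom is exchanged. The exchange at the carbonyl carbon, 4-fluorophenyl in place of (methoxycarbonyl)methyl, gives a number 40.1 percentage points higher from compound 1 to compound 3 (beyond the scatter), while 4-methylphenyl at that carbon gives a number 5.8 percentage points higher from compound 1 to compound 2 (within the scatter), so among these compounds an aromatic ring on the carbonyl is not enough by itself. Nothing available on these compounds bears on the cause of the rise.

As far as these compounds go, whether the rise is specific to fluoro stays open: chloro, methoxy or plain hydrogen at the same place would separate it from the loss of methyl. Also open, from the compounds shown here alone, is whether the inhibition at this single concentration holds up as a potency.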